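Compound 1 Loses Its 3-(1H-pyrrol-1-yl)propyl Group

The source may report more compounds than this note shows. Statements on the series, on what has been measured and on what is new or still open speak of the compounds shown alone.

Measured in (a functional assay on K562 cells (Homo sapiens) for antiproliferative activity, read by MTT assay, with a stated time of 48 h; a higher number here means a weaker inhibitor, a lower number a stronger inhibitor)
- compound 1 `Cn1cc(C2=C(c3nn(CCCn4cccc4)c4ncccc34)C(=O)NC2=O)c2ccccc21` gives (21600 nM)
- compound 2 `CN(C)CCCn1nc(C2=C(c3cn(C)c4ccccc34)C(=O)N(c3ccccc3)C2=O)c2cccnc21` gives (1700 nM)

Of these two numbers, compound 1 holds the higher (21600 nM), and compound 2 gives (1700 nM). The gap between the two lies beyond the scatter. Compound 3 `Cn1cc(C2=C(c3n[nH]c4ncccc34)C(=O)NC2=O)c2ccccc21` carries hydrogen in place of 3-(1H-pyrrol-1-yl)propyl on an aromatic nitrogen. Among the measured compounds shown here, no measured pair shows this change on its own, so the expectation is loose. A modest estimated step toward a lower number (a 2.2-fold lower number from compound 1 to compound 3 (0.33 log units; beyond the scatter)) is expected in (this assay), and it may not clear the scatter. Compound 3 is expected at (10000 nM), with an estimated range from (3000 nM) to (35000 nM).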

Compound 3, half-maximal inhibitory concentration: > 100000 nM
Compound 3: a limit, no number; the forecaster's own chance of this, stated with the estimate: 15%; middle value at least 10-fold (1.00 log units) from the limit.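

Compound 3 reaches a limit of the assay in this assay, not a number: the limit of > 100000 nM in this assay, at which 1 of the 3 values shown sits.

Hydrogen in place of 3-(1H-pyrrol-1-yl)propyl on this aromatic nitrogen gives an at least 4.6-fold higher number from compound 1 to compound 3 (0.66 log units; beyond the scatter). Among the compounds shown here, this is the first sign that the group on this nitrogen matters for the read-out, and that the core of compound 1 does not hold its activity with hydrogen there.

Going by these compounds, the full size of the step stays open. So does whether the propyl chain or the five-membered aromatic ring at its end carries the difference, and how a methyl group or a propyl chain ending in a carboxylic acid would read on this nitrogen.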